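A few compounds are considered here, and "the series" means these few. Any claim that something is new, unique, unknown or untested is made for them only; others in the source may bear on it.

Measured compounds:
Compound 1 `COc1ccc(Cc2cc(-c3ccc(OC)cc3)nn(CC(=O)Nc3ccc(Br)cc3)c2=O)cc1`: > 50000 nM
Compound 2 `COc1cc(Cc2cc(C)nn(CC(=O)Nc3ccc(Br)cc3)c2=O)cc(OC)c1`: > 50000 nM

In a functional assay on HL-60 cells (Homo sapiens), read by calcium flux (on this read-out higher numbers stand for an effect only at larger amounts of compound and lower numbers for an effect already at smaller amounts), compound 1 gives only a limit, > 50000 nM. In this assay compound 2 also gives only a limit, > 50000 nM. From the compounds shown here alone, both values sit at the limit of > 50000 nM in this assay, at which 2 of the 2 values shown sit, so compound 2 has no number of its own to stand on, and how far beyond that limit it lies is unknown. Compound 3 `Cc1cc(Cc2cccnc2)c(=O)n(CC(=O)Nc2ccc(Br)cc2)n1` is not yet measured. It differs from compound 2 in one place: pyridin-3-yl in place of 3,5-dimethoxyphenyl on a saturated chain carbon bound to an aromatic carbon. Going by the values given here, no measured step links the two measured compounds, so the expected step is taken as a number no higher from compound 2 to compound 3 (the limit leaves the size open), none beyond the usual scatter. Compound 3 is therefore expected near 50000 nM, between 5000 nM and 200000 nM.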

Compound 3, half-maximal effective concentration: > 50000 nM
Compound 3: no number, only a limit; the forecaster's own chance of this, stated with the estimate: 70%; the middle value lies on the limit itself.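

In this assay, going by these compounds alone, compound 2 and compound 3 both give only a limit, so no step between them can be read. Left open is whether pyridin-3-yl and 3,5-dimethoxyphenyl differ at all in this read-out.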